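The compounds below may be only part of what the source reports. "The series", "measured", "known", "first", "only" and "open" are said of these compounds alone.

In a functional assay on DU-145 cells (Homo sapiens) for inhibition, read by MTT assay, with a stated time of 72 h (on this read-out higher numbers stand for weaker inhibition of growth and lower numbers for stronger inhibition of growth), compound 2 `COc1ccc(CNC(=O)/C(C#N)=C/c2ccc(Br)o2)cc1` gives 12000 nM, the lowest of the two numbers shown. Compound 1 `N#C/C(=C\c1ccc([N+](=O)[O-])cc1)C(=O)c1c[nH]c2ccccc12` gives 59000 nM in this assay. Compound 3 `COc1ccc(CNC(=O)/C(C#N)=C/c2ccc(-c3ccccc3)o2)cc1` reaches only a limit in this assay, > 100000 nM, (the limit of > 100000 nM in this assay, at which 1 of the 3 values shown sits). Among the compounds with values here, the single measured step, an at least 8.3-fold higher number from compound 2 to compound 3 (0.92 log units; beyond the scatter), is thus open-ended in size. Compound 4 `COc1ccc(CNC(=O)/C(C#N)=C/c2ccc(Cl)cc2)cc1` differs from compound 2 by 4-chlorophenyl in place of 5-bromofuran-2-yl on a double-bonded chain carbon bound to a double-bonded chain carbon. Within the data shown here, no measured step exchanges this ring itself; the step from compound 2 to compound 3 alters only a substituent on that ring, so it is a loose guide. Compound 4 is therefore expected to sit near compound 2 or somewhat weaker, a step of a 1.7-fold higher number from compound 2 to compound 4 (0.22 log units; within the scatter). For compound 4 in this assay the estimate is 20000 nM, expected between 5000 nM and 80000 nM.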

Compound 4, concentration for 50% growth inhibition: 7000 nM
The estimate for compound 4 lay 2.9-fold (0.46 log units) above the measured number, and the stated range covers the measured number.
By their numbers in this assay, from the lowest: compounds 4 and 2 (each within the scatter of the next); then compound 1. At a limit, above all of these: compound 3.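

Earlier steps altered only a substituent on the ring; here the ring itself is exchanged, 4-chlorophenyl in place of 5-bromofuran-2-yl, and in this assay the outcome is a 1.7-fold lower number from compound 2 to compound 4 (0.23 log units; within the scatter). This place on the chain thus carries a six-membered aromatic ring of carbon only as well as a five-membered aromatic ring with 1 hetero atom, although the halogen changes in the same step. Nothing measured here gives a reason for this. The compounds shown leave open what the chlorine contributes, and whether an unsubstituted phenyl or a pyridine ring would give a similar number.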